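Swapping the benzoyl ring on an acylurea of a thiazole core

The compounds below may be only part of what the source reports. "The series", "measured", "known", "first", "only" and "open" are said of these compounds alone.

Measured so far:
Compound 1, `CN(C(=O)NC(=O)c1ccc(F)c(F)c1)c1nc(C(F)(F)F)c(C(=O)N/N=C/c2ccc(C(F)(F)F)cc2)s1`, with 5.93 ug/mL in a functional assay on MCF7 cells (Homo sapiens) for inhibition, read by MTT assay, with a stated time of 72 h; on this read-out lower numbers stand for stronger inhibition and higher numbers for weaker inhibition.
Compound 2, `CN(C(=O)NC(=O)c1cccc(C(F)(F)F)c1)c1nc(C(F)(F)F)c(C(=O)N/N=C/c2ccc(C(F)(F)F)cc2)s1`, with 6.5 ug/mL in this assay.
Compound 3, `CN(C(=O)NC(=O)c1cccc(C(F)(F)F)c1)c1nc(C(F)(F)F)c(C(=O)N/N=C/c2ccccc2C(F)(F)F)s1`, with 7.69 ug/mL in this assay.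

Compound 3 gives the highest of the three numbers, but its gaps to compound 2 and to compound 1 are both within the scatter, so no order among the three can be read from them. The two measured steps are small: a 1.1-fold higher number from compound 1 to compound 2 (0.04 log units; within the scatter) and a 1.2-fold higher number from compound 2 to compound 3 (0.07 log units; within the scatter).

Compound 4, `CN(C(=O)NC(=O)c1ccc(F)c(F)c1)c1nc(C(F)(F)F)c(C(=O)N/N=C/c2ccccc2C(F)(F)F)s1`, has not yet been measured. It differs from compound 3 in one place: 3,4-difluorophenyl in place of 3-(trifluoromethyl)phenyl on a carbonyl carbon. This is the same exchange as that from compound 1 to compound 2, only run the other way, and that step was within the scatter. Nothing in the measured compounds suggests that a change at this carbonyl carbon moves the number beyond the scatter, so compound 4 is expected to stay close to compound 3, with a 1.1-fold lower number from compound 3 to compound 4 (0.04 log units; within the scatter) as the expected step. The estimate for compound 4 in this assay is therefore 7 ug/mL, within a range from 3.5 ug/mL to 14 ug/mL.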

Compound 4, half-maximal inhibitory concentration: 8.21 ug/mL
Beside the measured number, compound 4's estimate is 1.2-fold (0.07 log units) below it, within the range that was stated.
By their numbers in this assay, from the lowest: compounds 1, 2, 3 and 4 (each within the scatter of the next).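

In this assay, the exchange of 3-(trifluoromethyl)phenyl for 3,4-difluorophenyl on a carbonyl carbon gives a 1.1-fold higher number from compound 3 to compound 4 (0.03 log units; within the scatter), so this change has now been read with two different groups at the other end of the molecule, and the two readings agree: the same change on two cores in this assay, a 1.1-fold higher number (0.04 log units; within the scatter) from compound 1 to compound 2 and a 1.1-fold lower number (0.03 log units; within the scatter) from compound 4 to compound 3, 1.2-fold (0.07 log units) apart, within the scatter of two such steps

The change from 4-(trifluoromethyl)phenyl to 2-(trifluoromethyl)phenyl on a carbon with a double bond to nitrogen, previously read only with the 3-(trifluoromethyl)phenyl group on the carbonyl carbon, now also gives a 1.4-fold higher number from compound 1 to compound 4 (0.14 log units; within the scatter) with 3,4-difluorophenyl there, and these readings agree as well: the same change on two cores in this assay, a 1.2-fold higher number (0.07 log units; within the scatter) from compound 2 to compound 3 and a 1.4-fold higher number (0.14 log units; within the scatter) from compound 1 to compound 4, 1.2-fold (0.07 log units) apart, within the scatter of two such steps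

The four compounds thus complete a square of two changes in which every listed step stays within the scatter, and neither change is seen to depend on the group at the other place.

All four compounds carry a fluorine-bearing phenyl group at both places, so they leave open whether the number would move beyond the scatter with a different group there. A carboxylic acid or an amine on either ring, or a longer alkyl chain in place of either ring, would test this.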